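Methyl to Hydrogen on a Shared Thiosemicarbazone Core

A few compounds are considered here, and "the series" means these few. Any claim that something is new, unique, unknown or untested is made for them only; others in the source may bear on it.

Compound 1 `O=C1Nc2ccc(OC(F)(F)F)cc2/C1=N/NC(=S)Nc1ccccc1`, in an ADME assay on RD cells (Homo sapiens) for cytotoxicity; a higher number here means that more compound is tolerated, a lower number that less compound is tolerated: > 25000 nM
Compound 2 `O=C1/C(=N\NC(=S)Nc2ccccc2)c2ccccc2N1c1ccccc1`, in this assay: > 25000 nM
Compound 3 `Cc1ccc2c(c1)/C(=N/NC(=S)Nc1ccccc1)C(=O)N2`, in this assay: > 25000 nM

Each of these three values is a limit of this assay, not a measured number. Compound 3 therefore stands at the same limit as the other two compounds, and the limit of > 25000 nM in this assay, at which 3 of the 3 values shown sit, sums the picture up. Among the measured compounds shown here, the only measured single change, a step that the two limits leave unreadable from compound 1 to compound 3, cannot be read because both ends are limits.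

Compound 4 `O=C1Nc2ccccc2/C1=N/NC(=S)Nc1ccccc1` differs from compound 3 by hydrogen in place of methyl on an aromatic carbon. No readable step bears on this change, so nothing beyond the scatter is expected in this assay, and compound 4 is expected to remain at the limit as well. The estimate for compound 4 is 40000 nM, with a range from 20000 nM to 100000 nM; the expected step is a step that the limit leaves unreadable from compound 3 to compound 4.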

Compound 4, half-maximal cytotoxic concentration: > 25000 nM
Compound 4: no number, only a limit (the forecaster's own chance of this, stated with the estimate: 85%); the middle value does not contradict the limit.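

The steps to compound 4 from compound 1, compound 2 and compound 3 cannot be read, since both ends of each are only limits: the limit of > 25000 nM in this assay, at which 4 of the 4 values shown sit.

The compounds shown leave open at what concentration any of them becomes toxic in this assay, and so whether these changes matter.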